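Adding a Methyl to the Side-Chain Amine: Expected Effect

This account rests on a few compounds, and the source may have more. Where it says the series, first, only, none or still open, it means among the compounds named here.

Compound 1 `CCNCCCOc1ccc2cc(NC(=O)c3ccc(O)c(CC=C(C)C)c3)c(=O)oc2c1C` and compound 2 `CCN(C)CCCOc1ccc2cc(NC(=O)c3ccc(O)c(CC=C(C)C)c3)c(=O)oc2c1C` share a core and differ by methyl in place of hydrogen on an amine nitrogen. In a functional assay on SK-BR-3 cells (Homo sapiens) for antiproliferative activity (a higher number here means a weaker inhibitor, a lower number a stronger inhibitor), compound 1 gives 720 nM, and compound 2 gives 730 nM, so that a 1.0-fold higher number from compound 1 to compound 2 (0.01 log units; within the scatter). Compound 3 `CC(C)=CCc1cc(C(=O)Nc2cc3ccc(OCCCNC(C)(C)C)c(C)c3oc2=O)ccc1O` carries a different amine: its core differs from that of compound 1 by tert-butyl in place of ethyl on an amine nitrogen, and in this assay compound 3 gives 660 nM. Compound 4 `CC(C)=CCc1cc(C(=O)Nc2cc3ccc(OCCCN(C)C(C)(C)C)c(C)c3oc2=O)ccc1O`, not yet measured, differs from compound 3 by methyl in place of hydrogen on an amine nitrogen, the same change as between compound 1 and compound 2, at a place described in the same words. For compound 4 the expected step is a 1.1-fold higher number from compound 3 to compound 4 (0.03 log units; within the scatter), resting on the earlier pair, because a 1.0-fold higher number from compound 1 to compound 2 (0.01 log units; within the scatter) shows this change leaving the number essentially unmoved. Compound 4 is therefore estimated at 700 nM in this assay, expected to fall between 400 nM and 1200 nM.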

Compound 4, half-maximal inhibitory concentration: 880 nM
Estimate against measurement, compound 4: 1.3-fold (0.10 log units) below; the measured number falls inside the stated range.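

In this assay, methyl in place of hydrogen on an amine nitrogen gives a 1.3-fold higher number from compound 3 to compound 4 (0.12 log units; within the scatter), and the two cores carrying this change do not part: the same change on two cores in this assay, a 1.0-fold higher number (0.01 log units; within the scatter) from compound 1 to compound 2 and a 1.3-fold higher number (0.12 log units; within the scatter) from compound 3 to compound 4, 1.3-fold (0.12 log units) apart, within the scatter of two such steps

Tert-butyl in place of ethyl on an amine nitrogen gives a 1.2-fold higher number from compound 2 to compound 4 (0.08 log units; within the scatter), the combined replacement of ethylamino by methyl(tert-butyl)amino gives a 1.2-fold higher number from compound 1 to compound 4 (0.09 log units; within the scatter), and the tert-butyl change also agrees across its two cores: the same change on two cores in this assay, a 1.1-fold lower number (0.04 log units; within the scatter) from compound 1 to compound 3 and a 1.2-fold higher number (0.08 log units; within the scatter) from compound 2 to compound 4, 1.3-fold (0.12 log units) apart, within the scatter of two such steps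

Going by these compounds alone, both changes therefore carry between these cores without a detectable difference, but with every step within the scatter, this shows only that the number holds steady across these four compounds, not that either change would behave alike on other cores or in other assays.

Still open, going by these compounds, is whether a cyclic amine such as piperidine or morpholine, or a primary amine, at the end of the chain would leave the number as steady. The same question stands for a shorter or longer chain between the oxygen and the amine.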